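The source may report more compounds than this note shows. Statements on the series, on what has been measured and on what is new or still open speak of the compounds shown alone.

In an ADME assay on BJ cells (Homo sapiens), read by MTT assay, with a stated time of 72 h (a higher number here means a weaker inhibitor, a lower number a stronger inhibitor), three related compounds have been tested so far. Compound 1 `Nc1nc(N)c2c(-c3cccs3)cn([C@@H]3O[C@H](CO)[C@@H](O)[C@H]3O)c2n1` gives > 100000 nM, which is a limit of the assay and not a number. Compound 2 `COc1nc(N)nc2c1c(-c1ccco1)cn2[C@@H]1O[C@H](CO)[C@@H](O)[C@H]1O` gives > 100000 nM, again a limit. Compound 3 `COc1nc(N)nc2c1c(-c1ccoc1)cn2[C@@H]1O[C@H](CO)[C@@H](O)[C@H]1O` gives > 100000 nM, also a limit, so its true value is not known. The whole set comes down to the limit of > 100000 nM in this assay, at which 3 of the 3 values shown sit.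

Compound 4 `COc1nc(N)nc2c1c(-c1cccs1)cn2[C@@H]1O[C@H](CO)[C@@H](O)[C@H]1O` has not yet been measured. It differs from compound 3 in one place: thiophen-2-yl in place of furan-3-yl on an aromatic carbon. This puts thiophen-2-yl in place of furan-3-yl on an aromatic carbon, so one five-membered aromatic ring with 1 hetero atom replaces another.

For the measured compounds named here, the one measured step that bears on this change is a step that the two limits leave unreadable from compound 2 to compound 3. It also exchanges one such ring for another, with furan-3-yl in place of furan-2-yl on an aromatic carbon, but it offers no size to carry over. Going by the values given here, with every value so far at the same limit, no change beyond the scatter is expected in this assay, and compound 4 will most likely be reported as a limit too. The step expected is a number no higher from compound 3 to compound 4 (the limit leaves the size open). The estimated value for compound 4 is 100000 nM, with an expected range from 30000 nM to 300000 nM.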

Compound 4, half-maximal inhibitory concentration: 99900 nM
Compound 4: the middle estimate sits 1.0-fold (0.00 log units) above what was measured; measured number inside the range.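

In this assay compound 4 is the only compound shown that gives a number and not a limit, 99900 nM. Thiophen-2-yl in place of furan-3-yl on an aromatic carbon gives a number no higher from compound 3 to compound 4 (the limit leaves the size open). Thiophen-2-yl in place of furan-2-yl on an aromatic carbon gives a number no higher from compound 2 to compound 4 (the limit leaves the size open). Methoxy in place of amino on an aromatic carbon gives a number no higher from compound 1 to compound 4 (the limit leaves the size open). On these data alone, the sizes of these steps cannot be read, as each starts from a limit, and the size of the change from either furan to thiophen-2-yl, or from amino to methoxy, stays unknown. The number does little to widen the picture, as the set still rests almost wholly at the edge of what the assay can report: the limit of > 100000 nM in this assay, at which 3 of the 4 values shown sit.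

As far as these compounds go, it remains open whether thiophen-3-yl, an amine or a carboxylic acid on this aromatic carbon would give a number clearly lower than that of compound 4. From the compounds shown here alone, it also remains open whether a longer chain in place of the methoxy group would do so.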